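The source may report more compounds than this note shows. Statements on the series, on what has been measured and on what is new or still open speak of the compounds shown alone.

Measured so far:

Compound 1, `Cn1ncc(Cl)c1-c1cc(C(=O)N[C@H]2CNCC[C@@H]2c2ccc(C(F)(F)F)cc2)oc1Cl`: 900 nM
Compound 2, `O=C(N[C@@H]1CNCC[C@H]1c1ccc(Cl)cc1)c1ccc(-c2ncnc3c2CCC3O)s1`: 24100 nM
Compound 3, `Cn1ncc(Cl)c1-c1cc(C(=O)N[C@@H]2CN[C@H](CCN3CCCC3)C[C@H]2c2ccc(Cl)c(Cl)c2)oc1Cl`: 1840 nM

These three compounds were tested in a functional assay on OVCAR-8 cells (Homo sapiens) for antiproliferative activity; a lower number here means a stronger inhibitor, a higher number a weaker inhibitor. Among them compound 3 holds the second highest number. Its nearest neighbour is compound 1, whose number is lower, a gap that lies beyond the usual scatter of repeated measurements, so compound 1 is the stronger inhibitor of the two. The furthest is compound 2, whose number is far higher, again beyond the scatter; compound 2 is the weakest inhibitor of the three.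

The next compound, compound 4, `CNC(=O)C[C@@H]1C[C@@H](c2ccc(Cl)c(Cl)c2)[C@H](NC(=O)c2cc(-c3c(Cl)cnn3C)c(Cl)o2)CN1`, comes from compound 3 by one change on a saturated chain carbon bound to a saturated ring carbon: methylcarbamoyl in place of (pyrrolidin-1-yl)methyl on a saturated chain carbon bound to a saturated ring carbon. A ring-bearing group leaves and a small open-chain group carrying an amide takes its place.

Going by the values given here, no measured pair in this set separates exactly this change, so its effect cannot be read off directly. The expectation is a modest step from compound 3 to compound 4 in this assay, toward a higher number, close to the edge of the scatter: a 1.6-fold higher number from compound 3 to compound 4 (0.21 log units; within the scatter). Compound 4 is therefore estimated at 3000 nM, with a likely range from 800 nM to 12000 nM.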

Compound 4, half-maximal inhibitory concentration: 1130 nM
Estimate against measurement, compound 4: 2.7-fold (0.42 log units) above, within the range that was stated.
By their numbers in this assay, from the lowest: compounds 1, 4 and 3 (each within the scatter of the next, the first and the last beyond it); then compound 2.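

In this assay, putting methylcarbamoyl in place of (pyrrolidin-1-yl)methyl on a saturated chain carbon bound to a saturated ring carbon gives a 1.6-fold lower number from compound 3 to compound 4 (0.21 log units; within the scatter), so compound 3 and compound 4 cannot be told apart here. Going by these compounds alone, this is the first direct reading of a change at this position, and the two groups are quite different: the group that leaves carries a five-membered non-aromatic ring and no hydrogen-bond donor, while the group that enters has no ring and carries a hydrogen-bond donor. Activity in this cell assay therefore does not depend on keeping the pyrrolidine ring at this position, at least for this one exchange, and no measured property of these compounds offers an explanation for this result.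

The compounds shown leave open how much the chain at this position contributes at all, since compound 1 has no such chain but also differs from compound 3 and compound 4 in its aromatic substituent. From the compounds shown here alone, it also remains unknown whether a carboxylic acid, a primary amine or a longer chain carrying the same amide would read the same way at this position.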